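The source may report more compounds than this note shows. Statements on the series, on what has been measured and on what is new or still open speak of the compounds shown alone.

Measured so far:
Compound 1, `CC(=O)ON(C(C)=O)c1ccc(-c2nc3ccccc3s2)cc1`: < 1 nM
Compound 2, `Cc1cc(-c2nc3ccccc3s2)ccc1N`: < 1 nM

In a functional assay on MCF7 cells (Homo sapiens) for cytotoxicity (a lower number here means a stronger inhibitor, a higher number a weaker inhibitor), compound 1 gives < 1 nM, which is a limit of the assay rather than a measured number. Compound 2, the amino-bearing partner, likewise gives < 1 nM in this assay, again a limit and not a number. For the measured compounds named here, compound 2 therefore stands where every value so far stands: the limit of < 1 nM in this assay, at which 2 of the 2 values shown sit. Going by the values given here, nothing in the data separates the two compounds, and no step between them can be sized.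

Compound 3, `CC(=O)ON(C(C)=O)c1ccc(-c2nc3ccccc3s2)cc1C`, is built from compound 2 by the change (acetoxy(acetyl)amino in place of amino on an aromatic carbon). The new group is the same one that compound 1 carries, and compound 1 sits at the limit in this assay. Among the compounds with values here, with both neighbours at the limit and no measured step to lean on, the expected movement a step that the limit leaves unreadable from compound 2 to compound 3 is none beyond the usual scatter, in either direction. Compound 3 is estimated at 0.7 nM in this assay, with a range from 0.2 nM to 3 nM, and a further reading that is only a limit would be no surprise.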

Compound 3, half-maximal inhibitory concentration: 55 nM
For compound 3 the middle estimate is 79-fold (1.90 log units) below the measured one, and the stated range ends below it.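

In this assay, for the compounds shown here, putting acetoxy(acetyl)amino in place of amino on the aromatic carbon ortho to a methyl group gives an at least 55-fold higher number from compound 2 to compound 3 (1.74 log units; beyond the scatter), the first change whose effect can be seen. Adding the methyl to the ring that already carries acetoxy(acetyl)amino gives an at least 55-fold higher number from compound 1 to compound 3 (1.74 log units; beyond the scatter), so among these compounds the number rises only where the methyl and the acetoxy(acetyl)amino group occur together, while either one without the other stays at the limit. Both steps are minimum sizes, because their starting values are limits of the assay and not measured numbers: the limit of < 1 nM in this assay, at which 2 of the 3 values shown sit.

As far as these compounds go, the true size of either step therefore remains unknown, and so does how far the effect depends on this exact pairing of groups. From the compounds shown here alone, it is also open whether a simple acetylamino group in place of acetoxy(acetyl)amino, or a chlorine atom or an ethyl group in place of the methyl, would raise the number in the same way.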